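Methyl to tert-Butyl on the Benzyl Arm

The source may hold more compounds than are shown below. What is called first, only, known or untested is meant among the compounds shown, and "the series" means these compounds.

Of the compounds shown here, three built on one shared core have been tested in an assay on isolated protein for inhibition of histone deacetylase 11 (Homo sapiens), read by mobility shift assay; on this read-out lower numbers stand for stronger inhibition and higher numbers for weaker inhibition. Compound 1 `O=C(NO)c1ccc(CN(Cc2ccc(C(F)(F)F)cc2)S(=O)(=O)c2c(F)c(F)c(F)c(F)c2F)cc1` gives > 1000 nM, which is a limit of the assay rather than a number. Compound 2 `CN(C)c1ccc(CN(Cc2ccc(C(=O)NO)cc2)S(=O)(=O)c2c(F)c(F)c(F)c(F)c2F)cc1` likewise gives > 1000 nM, again only a limit. Within the data shown here, compound 3 `Cc1ccc(CN(Cc2ccc(C(=O)NO)cc2)S(=O)(=O)c2c(F)c(F)c(F)c(F)c2F)cc1` is the sole compound with a numerical result, giving 73 nM in this assay, and so it stands alone at the readable end of the set. The step of an at least 13-fold lower number from compound 1 to compound 3 (1.13 log units; beyond the scatter) and the step of an at least 13-fold lower number from compound 2 to compound 3 (1.13 log units; beyond the scatter) run in the same direction, while the step that the two limits leave unreadable from compound 1 to compound 2 cannot be sized; both readable steps start from the limit of > 1000 nM in this assay, at which 2 of the 3 values shown sit, and therefore give only lower bounds on their size.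

Compound 4 `CC(C)(C)c1ccc(CN(Cc2ccc(C(=O)NO)cc2)S(=O)(=O)c2c(F)c(F)c(F)c(F)c2F)cc1` differs from compound 3 by tert-butyl in place of methyl on an aromatic carbon. Among the measured compounds shown here, none of the measured steps exchanges methyl for another alkyl group at this carbon; the two readable steps show only that the substituent here can move the number a long way. Compound 4 is therefore expected to land at about 200 nM, within a range from 40 nM to 1500 nM in this assay. This corresponds to an estimated step of a 2.7-fold higher number from compound 3 to compound 4 (0.44 log units; beyond the scatter), a modest loss that may still lie close to the scatter.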

Compound 4, half-maximal inhibitory concentration: 88 nM
Compound 4: the middle estimate sits 2.3-fold (0.36 log units) above what was measured; the measured number falls inside the stated range.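

In this assay, among these compounds, the step of a 1.2-fold higher number from compound 3 to compound 4 (0.08 log units; within the scatter) lies within the scatter, so the 4-methylbenzyl and 4-(tert-butyl)benzyl arms cannot be told apart, which the earlier compounds, with methyl as the only alkyl group at this carbon, could not show. This exchange of methyl for tert-butyl therefore keeps the number at the readable end of the set, and the new steps of an at least 11-fold lower number from compound 2 to compound 4 (1.05 log units; beyond the scatter) and an at least 11-fold lower number from compound 1 to compound 4 (1.05 log units; beyond the scatter) run the same way as those from the same two compounds to compound 3, so compound 3 no longer stands alone against dimethylamino and trifluoromethyl at this carbon. Both new steps give only a lower bound on their size, because each starts from a limit of the assay rather than a number: the limit of > 1000 nM in this assay, at which 2 of the 4 values shown sit.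

How far the alkyl tolerance reaches stays open, since nothing shown tells whether ethyl, isopropyl, a longer chain or cyclohexyl at this carbon would sit with methyl and tert-butyl. From the compounds shown here alone, it is equally open whether a methoxy group, chlorine or an unsubstituted phenyl ring here would do so, and the order of compound 1 and compound 2 cannot be read.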